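Trimming the Benzylamino Group Down to a Hydroxy

A few compounds are considered here, and "the series" means these few. Any claim that something is new, unique, unknown or untested is made for them only; others in the source may bear on it.

Measured so far:
Compound 1, `CC(NCc1ccccc1)c1nc([N+](=O)[O-])c(Sc2c(Cl)cncc2Cl)s1`: 26800 nM
Compound 2, `Cc1ccc(CNC(=O)c2nc([N+](=O)[O-])c(Sc3c(Cl)cncc3Cl)s2)cc1`: 3650 nM

Both were tested in an assay on isolated protein for inhibition of ubiquitin carboxyl-terminal hydrolase 7 (Homo sapiens), read by fluorescence, with stated times of 30 min and 3 h; a higher number here means a weaker inhibitor, a lower number a stronger inhibitor. Compound 1 has the highest of the two numbers, so it is the weaker inhibitor of the pair; compound 2 lies lower by a gap that is beyond the usual scatter. The two differ in more than one place, so the gap is noted without explanation.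

Compound 3, `CC(O)c1nc([N+](=O)[O-])c(Sc2c(Cl)cncc2Cl)s1`, has not yet been measured. It differs from compound 1 in one place: hydroxy in place of benzylamino on a saturated chain carbon bound to an aromatic carbon and a saturated chain carbon. The group with the six-membered aromatic ring of carbon only leaves, and a far smaller hydroxy enters on the same saturated chain carbon. Among the measured compounds shown here, no pair of measured compounds shows what such a change does here. Since compound 1 already stands at 26800 nM, the expected step is a modest move toward a weaker inhibitor, a 1.9-fold higher number from compound 1 to compound 3 (0.27 log units; within the scatter). Compound 3 is therefore estimated to give 50000 nM, with a likely range from 15000 nM to 200000 nM, and a fair chance that this assay reports only a limit.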

Compound 3, half-maximal inhibitory concentration: 6950 nM
For compound 3 the middle estimate is 7.2-fold (0.86 log units) above the measured one; the measured number lies below the stated range.
By their numbers in this assay, from the lowest: compounds 2 and 3 (each within the scatter of the next); then compound 1.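

In this assay the swap of benzylamino for hydroxy gives a real gain (a 3.9-fold lower number from compound 1 to compound 3 (0.59 log units; beyond the scatter)), so inhibition at this saturated chain carbon does not depend on the benzylamino group or its six-membered aromatic ring of carbon only. The two groups have the same counts of hydrogen-bond donors and acceptors, yet the much smaller hydroxy gives the lower number, which shows that this position responds to what is placed on it. No measurement here explains the gain.

From the compounds shown here alone, it remains open whether the hydroxy itself contributes or whether removing the benzylamino group is enough, which a plain hydrogen on this carbon would help to settle. A methoxy group or a small amine such as amino or methylamino would show how far the position tolerates other small groups.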